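The compounds below may be only part of what the source reports. "The series", "measured", "known", "first", "only" and "open" are said of these compounds alone.

Compound 1 `CCCCc1cc2c(=O)c(C(=O)OCC)c[nH]c2cc1OCCOc1ccccc1`: > 20000 nM, a limit
Compound 2 `COC(=O)c1c[nH]c2cc(-c3ccccc3)ccc2c1=O`: > 20000 nM, a limit
Compound 3 `CCOc1ccc2[nH]cc(C(=O)OC)c(=O)c2c1`: > 20000 nM, a limit

These three compounds were tested in an ADME assay on J774 cells (Mus musculus) for cytotoxicity; on this read-out higher numbers stand for an effect only at larger amounts of compound and lower numbers for an effect already at smaller amounts. Compound 1 stands at the limit of > 20000 nM in this assay, at which 3 of the 3 values shown sit, so its result is a limit and not a number. Compound 4 `CCCCc1cc2c(=O)c(C(=O)NCCO)c[nH]c2cc1OCCOc1ccccc1` has not yet been measured. It carries (2-hydroxyethyl)amino in place of ethoxy on a carbonyl carbon. For the measured compounds named here, no measured step shows what such a change does. With compound 1 at > 20000 nM, a limit, no step beyond the scatter is expected in this assay. The estimated change is a step that the limit leaves unreadable from compound 1 to compound 4. Compound 4 is estimated at 25000 nM, within an expected range from 10000 nM to 60000 nM. A report of only a limit would be the likeliest outcome.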

Compound 4, half-maximal effective concentration: > 20000 nM
Compound 4: only a limit was reported; the forecaster's own chance of this, stated with the estimate: 80%; the middle value does not contradict the limit.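

For the compounds shown here, compound 1 and compound 4 both returned only limits, so no step between them can be read. The compounds shown leave open whether (2-hydroxyethyl)amino in place of ethoxy on a carbonyl carbon changes the result in this assay at all.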